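Methoxy for Chloro: Two Pairs Compared

The source may report more compounds than this note shows. Statements on the series, on what has been measured and on what is new or still open speak of the compounds shown alone.

Compound 1 `Cc1ccc2nc(-c3ccc(Cl)cc3)cc(C(=O)OCc3ccccc3)c2c1` and compound 2 `COc1ccc(-c2cc(C(=O)OCc3ccccc3)c3cc(C)ccc3n2)cc1` differ by methoxy in place of chloro on an aromatic carbon. In a functional assay on MDA-MB-231 cells (Homo sapiens) for antiproliferative activity, read by MTT assay, with a stated time of 48 h (on this read-out higher numbers stand for weaker inhibition and lower numbers for stronger inhibition), compound 1 reaches only a limit, > 100000 nM. Compound 2 gives 20500 nM. Together these make an at least 4.8-fold lower number from compound 1 to compound 2 (0.68 log units; beyond the scatter), and its size is known only as a bound, since two of the three values sit at the limit of > 100000 nM in this assay, at which 2 of the 3 values shown sit.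

Compound 3 `Clc1ccc(-c2cc(COCc3ccccc3)c3cc(Cl)c(Cl)cc3n2)cc1` and compound 4 `COc1ccc(-c2cc(COCc3ccccc3)c3cc(Cl)c(Cl)cc3n2)cc1` carry the same kind of change, (methoxy in place of chloro on an aromatic carbon); the difference between the two cores is not broken down here. In this assay compound 3 shows only a limit, > 100000 nM.

From compound 3 to compound 4 a step of an at least 2.5-fold lower number from compound 3 to compound 4 (0.39 log units; beyond the scatter) is expected, resting on an at least 4.8-fold lower number from compound 1 to compound 2 (0.68 log units; beyond the scatter). Compound 4 is therefore estimated at 40000 nM, with a range from 10000 nM to 200000 nM.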

Compound 4, half-maximal inhibitory concentration: > 100000 nM
Compound 4: a limit, no number; the forecaster's own chance of this, stated with the estimate: 35%; middle value at least 2.5-fold (0.39 log units) away from the limit.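

Among these compounds, compound 3 and compound 4 both give only limits, so no step between them can be read: the limit of > 100000 nM in this assay, at which 3 of the 4 values shown sit.

Going by these compounds, whether methoxy in place of chloro changes the number on the core of compound 3 stays open.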